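Swapping the halogen on the benzyl arm

The source may report more compounds than this note shows. Statements on the series, on what has been measured and on what is new or still open speak of the compounds shown alone.

Measured so far:
Compound 1, `COc1cccc(C(=O)Oc2ccc3c(=O)c(-c4cc(OC)c(OC)cc4OC)coc3c2)c1`: > 10000 nM
Compound 2, `COc1cc(OC)c(-c2coc3cc(OCc4ccccc4F)ccc3c2=O)cc1OC`: 1280 nM
Compound 3, `COc1cc(OC)c(-c2coc3cc(OCc4ccc(Br)cc4)ccc3c2=O)cc1OC`: 1050 nM

In a functional assay on HepG2 cells (Homo sapiens) for antiproliferative activity, read by MTT assay, with a stated time of 24 h (a higher number here means a weaker inhibitor, a lower number a stronger inhibitor), compound 1 reaches only a limit of the assay, > 10000 nM. Compound 2 gives 1280 nM, and compound 3 gives 1050 nM. Compound 3 marks the low side of the two numbers shown, but its difference from compound 2, a 1.2-fold lower number from compound 2 to compound 3 (0.09 log units; within the scatter), is within the scatter, so the two cannot be told apart. Against compound 1 the step of an at least 9.5-fold lower number from compound 1 to compound 3 (0.97 log units; beyond the scatter) is beyond the scatter.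

Compound 4, `COc1cc(OC)c(-c2coc3cc(OCc4cccc(Cl)c4)ccc3c2=O)cc1OC`, differs from compound 3 in one place: 3-chlorophenyl in place of 4-bromophenyl on a saturated chain carbon bound to an oxygen on an aromatic ring. The step that bears on this is a 1.2-fold lower number from compound 2 to compound 3 (0.09 log units; within the scatter), where one halogen-bearing phenyl replaced another at the same place and the number stayed within the scatter. The steps of an at least 7.8-fold lower number from compound 1 to compound 2 (0.89 log units; beyond the scatter) and an at least 9.5-fold lower number from compound 1 to compound 3 (0.97 log units; beyond the scatter) concern the exchange of the acyl group for a benzyl group and so touch a different part. No step beyond the scatter is therefore expected, a 1.0-fold higher number from compound 3 to compound 4 (0.02 log units; within the scatter). Compound 4 is estimated at 1100 nM, in the range 500 nM to 2500 nM.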

Compound 4, half-maximal inhibitory concentration: 750 nM
Compound 4: the middle estimate sits 1.5-fold (0.17 log units) above what was measured, within the range that was stated.
By their numbers in this assay, from the lowest: compounds 4, 3 and 2 (each within the scatter of the next). At a limit, above all of these: compound 1.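

In this assay, the chlorine-bearing arm reads like the two earlier halogen-bearing arms: 3-chlorophenyl in place of 4-bromophenyl gives a 1.4-fold lower number from compound 3 to compound 4 (0.15 log units; within the scatter) and 3-chlorophenyl in place of 2-fluorophenyl gives a 1.7-fold lower number from compound 2 to compound 4 (0.23 log units; within the scatter). This position therefore now tolerates a third halogen and a third ring pattern with no change that can be told from scatter. The step from (3-methoxyphenyl)carbonyl to 3-chlorobenzyl also holds up, as an at least 13-fold lower number from compound 1 to compound 4 (1.12 log units; beyond the scatter), although the compound 1 end of that step is a limit of the assay and not a number: the limit of > 10000 nM in this assay, at which 1 of the 4 values shown sits.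

On these data alone, it remains open whether a benzyl ring carrying an amine or a carboxylic acid instead of a halogen would read the same. Among these compounds, each halogen also appears at only one ring place, so the identity of the halogen and its place cannot be separated.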